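The source may report more compounds than this note shows. Statements on the series, on what has been measured and on what is new or still open speak of the compounds shown alone.

Compound 1 `COC(=O)C1=C(CN2CCNCC2)NC(c2nccs2)=NC1(C)c1ccc(F)cc1`, compound 2 `COC(=O)C1=C(CN2CC3CC2CO3)NC(c2nccs2)=NC1(C)c1ccc(F)cc1` and compound 3 `COC(=O)C1=C(CN2CCNC(=O)C2)NC(c2nccs2)=NC1(C)c1ccc(F)cc1` share one core and differ only in the group on a saturated chain carbon bound to a double-bonded ring carbon. In an ADME assay on microsomes from liver (Mus musculus) for metabolic stability, read by LC-MS, using NADPH, with stated times of 10 min and 30 min, tested at 1 uM (on this read-out higher numbers stand for fast clearance and lower numbers for slow clearance), compound 1 gives 39 mL/min/kg, compound 2 gives 84 mL/min/kg and compound 3 gives 81 mL/min/kg. That places compound 3 at the high end of the three, level with compound 2, as the data show a 1.0-fold lower number from compound 2 to compound 3 (0.02 log units; within the scatter) and a 2.1-fold higher number from compound 1 to compound 3 (0.32 log units; beyond the scatter).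

Compound 4 `COC(=O)C1=C(CN2CCC(O)C2)NC(c2nccs2)=NC1(C)c1ccc(F)cc1` has not yet been measured. Its change is 3-hydroxypyrrolidin-1-yl in place of 3-oxopiperazin-1-yl on a saturated chain carbon bound to a double-bonded ring carbon. Among the measured compounds shown here, no measured step makes this exact swap, so the evidence is indirect. The two steps that bear on it are a 2.2-fold higher number from compound 1 to compound 2 (0.33 log units; beyond the scatter) and a 2.1-fold higher number from compound 1 to compound 3 (0.32 log units; beyond the scatter), and both are modest. Together they show that two quite different groups gave nearly the same number, while compound 1 is the only one of the three that stands apart. The entering group resembles the group of compound 2 in its counted atoms more than it does the group of compound 1, so a number near the upper pair seems likelier. In this assay the expected change is a 1.2-fold lower number from compound 3 to compound 4 (0.08 log units; within the scatter), a slightly lower number and no real step beyond the scatter. Compound 4 is estimated at 68 mL/min/kg, with an expected range from 38 mL/min/kg to 105 mL/min/kg.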

Compound 4, clearance: 83 mL/min/kg
Compound 4: middle estimate off by 1.2-fold (0.09 log units), on the low side; the range from low to high includes it.
By their numbers in this assay, from the lowest: compound 1; then compounds 3, 4 and 2 (each within the scatter of the next).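

In this assay, replacing the six-membered 3-oxopiperazin-1-yl with the five-membered 3-hydroxypyrrolidin-1-yl gives a 1.0-fold higher number from compound 3 to compound 4 (0.01 log units; within the scatter), and setting it against the two-ring group gives a 1.0-fold lower number from compound 2 to compound 4 (0.01 log units; within the scatter). At this position, then, a third group of different build joins the upper level, so neither ring size, the carbonyl, nor the hydroxyl separates these three compounds on this read-out. Piperazin-1-yl now stands apart from three groups rather than two, with a 2.1-fold higher number from compound 1 to compound 4 (0.33 log units; beyond the scatter), and nothing measured here explains that gap.

The compounds shown leave open whether the lower clearance number belongs to piperazin-1-yl alone or extends to close relatives, such as a piperazine ring carrying a methyl group, a morpholine ring, or a plain pyrrolidine ring without the hydroxyl. Among the compounds shown here, they also cannot tell whether the upper level reflects something shared by the three groups or is simply a ceiling for the rest of the molecule, since every comparison so far changes only this one group on the shared core.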